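This account rests on a few compounds, and the source may have more. Where it says the series, first, only, none or still open, it means among the compounds named here.

Measured compounds:
- compound 1, `COc1cc(-c2nn(-c3cccc(NC(=O)c4cccc(C(F)(F)F)c4)c3)cc2-c2ccncc2)ccc1Cl`, in a functional assay on 786-0 cells (Homo sapiens) for inhibition, read by sulforhodamine B assay, with a stated time of 48 h (on this read-out lower numbers stand for stronger inhibition of growth and higher numbers for weaker inhibition of growth), compound 1 gives 2450 nM
- compound 2, `COc1cc(-c2nn(-c3cccc(NC(=O)Nc4ccc(Cl)c(C(F)(F)F)c4)c3)cc2-c2ccncc2)ccc1Cl`, in this assay compound 2 gives 1610 nM

Compound 2 has the lowest of the two numbers, but its neighbour compound 1 sits within the scatter, so the two cannot be told apart. Within the data shown here, the only step recorded, a 1.5-fold lower number from compound 1 to compound 2 (0.18 log units; within the scatter), is itself within the scatter and is the sole guide for the next compound. Compound 3, `COc1cc(-c2nn(-c3cccc(NC(=O)c4ccccc4)c3)cc2-c2ccncc2)ccc1Cl`, is not yet measured. It differs from compound 2 by phenyl in place of (4-chloro-3-(trifluoromethyl)phenyl)amino on a carbonyl carbon. This change reverses the direction of the step from compound 1 to compound 2 and also drops the trifluoromethyl group that compound 1 carries, so the data do not contain a matching step. The expectation is a modest rise in the number, of the order of a 2.5-fold higher number from compound 2 to compound 3 (0.40 log units; beyond the scatter), going beyond the scatter only slightly if at all. Compound 3 is therefore estimated to give 4000 nM in this assay, within a range of 1500 nM to 12000 nM.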

Compound 3, concentration for 50% growth inhibition: 1520 nM
Beside the measured number, compound 3's estimate is 2.6-fold (0.42 log units) above it, within the range that was stated.
By their numbers in this assay, from the lowest: compounds 3, 2 and 1 (each within the scatter of the next).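

In this assay, phenyl in place of (4-chloro-3-(trifluoromethyl)phenyl)amino on the carbonyl carbon gives a 1.1-fold lower number from compound 2 to compound 3 (0.02 log units; within the scatter), and hydrogen in place of trifluoromethyl on the aromatic carbon gives a 1.6-fold lower number from compound 1 to compound 3 (0.21 log units; within the scatter). Both steps lie within the scatter, so among these three compounds neither the trifluoromethyl group nor the whole (4-chloro-3-(trifluoromethyl)phenyl)amino group makes a difference that this read-out can detect, and a plain phenyl on the carbonyl carbon cannot be told apart from either larger group. No measurement at hand explains why these numbers lie so close together.

On these data alone, it remains open whether a group of another kind on that phenyl ring, such as an amine or a carboxylic acid, would move the number beyond the scatter. The same question stands for a longer chain in place of the phenyl on the carbonyl carbon.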